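The source may report more compounds than this note shows. Statements on the series, on what has been measured and on what is new or still open speak of the compounds shown alone.

Compound 1 `COc1cccc(CNc2n[nH]c(-c3cccnc3Nc3cc(OC)cc(OC)c3)n2)c1` and compound 2 `COc1ccc(CNc2n[nH]c(-c3cccnc3Nc3cc(OC)cc(OC)c3)n2)cc1` share one core; compound 3 `COc1cccc(CNc2n[nH]c(-c3cccnc3Oc3cc(OC)cc(OC)c3)n2)c1` and compound 4 `COc1ccc(CNc2n[nH]c(-c3cccnc3Oc3cc(OC)cc(OC)c3)n2)cc1` share another. The difference between the two cores is not broken down here. In a functional assay on A-431 cells (Homo sapiens), tested at 0.1 uM (a lower number here means less inhibition, a higher number more inhibition at the concentration tested (going by the name of the read-out)), compound 1 gives 71%, compound 2 gives 22%, and compound 3 gives 32%. The numbers of compound 3 and compound 2 lie within the scatter of each other, while compound 1 stands beyond the scatter from both. The change from compound 1 to compound 2 is 4-methoxyphenyl in place of 3-methoxyphenyl on a saturated chain carbon bound to a nitrogen on an aromatic ring, and in this assay it made a step of a number 49 percentage points lower from compound 1 to compound 2 (beyond the scatter). The change from compound 3 to compound 4 is 4-methoxyphenyl in place of 3-methoxyphenyl on a saturated chain carbon bound to a nitrogen on an aromatic ring; the place is described in the same words for both pairs, so this is the same change made on the second core, and it occurs twice among the compounds shown. Within the data shown here, only one measured instance exists, and the read-out cannot fall below its floor. Compound 4 is expected to show a step of a number 24 percentage points lower from compound 3 to compound 4 (beyond the scatter) in this assay. That expected step is smaller than the earlier one because compound 3 starts from 32%, which leaves less room. The estimate for compound 4 in this assay is 8%, with a range from 0% to 25%.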

Compound 4, a percentage reported as inhibition, at one concentration (the size of the read-out at that concentration, not a potency): 28%
Estimate against measurement, compound 4: 20 percentage points below; measured number above the stated range.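

In this assay, putting 4-methoxyphenyl in place of 3-methoxyphenyl on a saturated chain carbon bound to a nitrogen on an aromatic ring does not transfer at the same size from the core of compound 1 to the core of compound 3: the same change on two cores in this assay, a number 49 percentage points lower (beyond the scatter) from compound 1 to compound 2 and a number 4 percentage points lower (within the scatter) from compound 3 to compound 4, 45 percentage points apart, beyond the scatter of two such steps On the second core the change gives a number 4 percentage points lower from compound 3 to compound 4 (within the scatter), so the large drop on the first core cannot be treated as a fixed contribution of this change across the series. Among these compounds, with only two pairs at a single concentration, the result shows that the outcome of this change depends on the core in these compounds, but it does not show which feature of the core is responsible or how the change would behave on any further core.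

As far as these compounds go, it remains open how a plain phenyl, a 3-chlorophenyl or a 3-hydroxyphenyl at the same place would read on each core. From the compounds shown here alone, it is also open whether a longer chain carrying the 3-methoxyphenyl would keep the same gap between the two cores.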